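The source may report more compounds than this note shows. Statements on the series, on what has been measured and on what is new or still open speak of the compounds shown alone.

Measured to date in an assay on CHO cells for agonist activity at Glucose-dependent insulinotropic receptor (Homo sapiens), read by a luciferase reporter and cAMP accumulation, with a stated time of 2 h; on this read-out higher numbers stand for an effect only at larger amounts of compound and lower numbers for an effect already at smaller amounts:

compound 1 `CC(C)c1noc(N2CCC(Oc3cc(N4CCc5cc(N6CCCCC6=O)ccc54)ncn3)CC2)n1` gives 17 nM
compound 2 `CC(C)c1noc(N2CCC(Oc3cc(N4CCc5cc(N6CCOCC6=O)ccc54)ncn3)CC2)n1` gives 15 nM
compound 3 `CC(C)c1noc(N2CCC(Oc3cc(N4CCc5cc(N6CCCNS6(=O)=O)ccc54)ncn3)CC2)n1` gives 24 nM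

Compound 1 stands second highest of the three numbers. Its nearest neighbour is compound 2, with a 1.1-fold lower number from compound 1 to compound 2 (0.05 log units; within the scatter); the furthest is compound 3, with a 1.4-fold higher number from compound 1 to compound 3 (0.15 log units; within the scatter). Compound 2 and compound 3 lie apart by a 1.6-fold higher number from compound 2 to compound 3 (0.20 log units; within the scatter). All three numbers thus sit together within the usual scatter, and no ordering among them can be claimed.

Compound 4 `CC(C)c1noc(N2CCC(Oc3cc(N4CCc5cc(N6CCCS6(=O)=O)ccc54)ncn3)CC2)n1` is not yet measured. Relative to compound 1 the change is a group of 7 heavy atoms (3 carbon, 1 nitrogen, 2 oxygen, 1 sulfur; one five-membered non-aromatic ring with 2 hetero atoms) in place of a group of 7 heavy atoms (5 carbon, 1 nitrogen, 1 oxygen; one six-membered non-aromatic ring with 1 hetero atom), on an aromatic carbon.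

For the measured compounds named here, the steps that bear on this are the two exchanges at the same position already seen: compound 1 to compound 2 and compound 1 to compound 3, both of them within the scatter despite moving between one-hetero-atom, two-hetero-atom and three-hetero-atom six-membered rings. The ring entering in compound 4 is five-membered with two hetero atoms, which is a somewhat different shape from anything measured so far, so some extra uncertainty remains. On the evidence available, however, no step beyond the scatter is expected in this assay, in either direction.

For compound 4 the estimate is 20 nM, with a range of 8 nM to 50 nM, which corresponds to an expected step of a 1.2-fold higher number from compound 1 to compound 4 (0.07 log units; within the scatter).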

Compound 4, half-maximal effective concentration: 9.7 nM
Beside the measured number, compound 4's estimate is 2.1-fold (0.31 log units) above it; low and high end bracket the measured number.
By their numbers in this assay, from the lowest: compounds 4, 2, 1 and 3 (each within the scatter of the next, the first and the last beyond it).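

Notes on the group on the aromatic carbon para to a fused ring: in this assay, a five-membered non-aromatic ring with 2 hetero atoms can take the place of a six-membered one without a step beyond the scatter, with a 1.8-fold lower number from compound 1 to compound 4 (0.24 log units; within the scatter) against 2-oxopiperidin-1-yl and a 1.5-fold lower number from compound 2 to compound 4 (0.19 log units; within the scatter) against 3-oxomorpholin-4-yl. For the compounds shown here, this place nevertheless separates two groups for the first time: a 2.5-fold lower number from compound 3 to compound 4 (0.39 log units; beyond the scatter) is a modest step beyond the scatter, between the two sulfur-bearing rings, while compound 1 and compound 2 each stay within the scatter of both. Nothing measured on these groups accounts for that step.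

As far as these compounds go, whether a ring is needed here at all remains open: an open-chain methanesulfonyl group, a primary amine or a carboxylic acid on the same aromatic carbon would address that. From the compounds shown here alone, the four compounds also vary in this one place only, so it is open whether the modest separation between the two sulfur-bearing rings would persist with another group elsewhere on the shared core.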